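A Second Fluoro Group on a Pair at the Limit

The source may hold more compounds than are shown below. What is called first, only, known or untested is meant among the compounds shown, and "the series" means these compounds.

This account follows two compounds of a shared core and another compound that differs from compound 2 in one place. Compound 1 `Cc1nn(C)c(Oc2ccc(F)cc2)c1/C=N\CCCCCOc1cc2oc(=O)cc(C)c2cc1Cl` was tested in a functional assay on U-87MG ATCC cells for antiproliferative activity against U-87 MG (Homo sapiens), read by MTT assay, with a stated time of 72 h; on this read-out higher numbers stand for weaker inhibition and lower numbers for stronger inhibition. In this assay compound 1 reached only the limit > 25000 nM and no number. Compound 2 `Cc1nn(C)c(Oc2ccccc2F)c1/C=N\CCCCCCOc1cc2oc(=O)cc(C)c2cc1Cl` was tested in the same way. In this assay compound 2 likewise gave only the limit > 25000 nM and no number. Compound 2 therefore stands at the limit of > 25000 nM in this assay, at which 2 of the 2 values shown sit, and nothing shown separates it from compound 1. Compound 3 `Cc1nn(C)c(Oc2cccc(F)c2F)c1/C=N\CCCCCCOc1cc2oc(=O)cc(C)c2cc1Cl` differs from compound 2 by fluoro in place of hydrogen on an aromatic carbon. For the measured compounds named here, no step between measured compounds is available for a change of this kind, so the size of the step can only be expected from the limits themselves. A change this small is expected to give no step beyond the scatter in either direction. On that basis compound 3 is expected to show 30000 nM, within a range of 10000 nM to 100000 nM, most likely once more as a limit rather than a number. The step that the limit leaves unreadable from compound 2 to compound 3 is estimated to be none beyond the scatter.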

Compound 3, half-maximal inhibitory concentration: > 25000 nM
Compound 3: a limit, no number (the forecaster's own chance of this, stated with the estimate: 80%); the middle value lies beyond the limit too.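

In this assay compound 3 also reached only a limit and no number, > 25000 nM. No step can be read from compound 2 to compound 3, for all the compounds sit at the same limit: the limit of > 25000 nM in this assay, at which 3 of the 3 values shown sit. The compounds shown leave open whether the added fluoro group changes the activity of this shared core at all.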